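From Triazole to Methylpyrazole on a Shared Core

The compounds below may be only part of what the source reports. "The series", "measured", "known", "first", "only" and "open" are said of these compounds alone.

Within the data shown here, compound 1 `c1ccc(-c2nc[nH]n2)c(NCC2=NCCN2)c1` stands at the lowest of the two numbers measured so far. In an in vitro functional assay on cells (Fibroblast) for agonist activity at Alpha-1A adrenergic receptor (Homo sapiens) (on this read-out lower numbers stand for an effect already at smaller amounts and higher numbers for an effect only at larger amounts of compound), compound 1 gives 0.794 nM. Compound 2 `CCn1ccc(-c2ccccc2NCC2=NCCN2)n1` gives 25.1 nM in this assay, a higher number by a margin beyond the usual scatter. Compound 3 `Cn1cc(-c2ccccc2NCC2=NCCN2)cn1` has not yet been measured. It differs from compound 1 in one place: 1-methyl-1H-pyrazol-4-yl in place of 1H-1,2,4-triazol-3-yl on an aromatic carbon. Among the measured compounds shown here, no measured pair shows this exact change. Compound 2 also carries a pyrazole on the shared core, and its value of 25.1 nM lies well above that of compound 1, so a shift toward higher numbers seems likely here too. The expected step is a 13-fold higher number from compound 1 to compound 3 (1.10 log units; beyond the scatter), toward higher numbers. Compound 3 is therefore estimated at 10 nM in this assay, within a range of 2 nM to 60 nM.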

Compound 3, half-maximal effective concentration: 398 nM
Compound 3: middle estimate off by 40-fold (1.60 log units), on the low side; the whole stated range lies below it.
By their numbers in this assay, from the lowest: compound 1; then compound 2; then compound 3.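

In this assay, putting 1-methyl-1H-pyrazol-4-yl in place of 1H-1,2,4-triazol-3-yl on this aromatic carbon, ortho to a group of 7 heavy atoms, gives a 500-fold higher number from compound 1 to compound 3 (2.70 log units; beyond the scatter), so this place on the shared core responds strongly to the identity of the five-membered ring. Among these compounds, the single step changes several things together: the ring goes from 3 hetero atoms to 2, from 1 hydrogen-bond donor to 0 hydrogen-bond donors, and it gains a methyl group. Nothing given here accounts for the size of this step.

The compounds shown do not separate these differences, so it remains open which of them carries the step. Also open, from the compounds shown here alone, is how an unmethylated 1H-pyrazol-4-yl group or a 1-methyl-1H-1,2,4-triazol-3-yl group would read at this place.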